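The compounds below may be only part of what the source reports. "The series", "measured", "known", "first", "only" and "open" are said of these compounds alone.

Measured so far:
- compound 1, `COc1ccc(/C=C2\CN(CC(=O)O)c3c(Cl)cccc3C2=O)c(OC)c1OC`: 23.6%
- compound 2, `Cc1cccc2c1N(CC(=O)O)C/C(=C\c1ccc(N(C)C)cc1)C2=O`: 13.2%

Of the compounds shown here, two share a core and have been tested in an assay on HL-60 cells for inhibition of glutathione S-transferase P (Homo sapiens), read by spectrophotometry, tested at 20 uM; on this read-out lower numbers stand for less inhibition and higher numbers for more inhibition at the one concentration tested (going by the name of the read-out). In this assay compound 1 gives 23.6%, while compound 2 gives 13.2%. For the measured compounds named here, compound 2 thus stands at the lowest of the two numbers, and its only neighbour, compound 1, sits higher by a gap that lies beyond the usual scatter of this measurement. Going by the values given here, no step between two measured compounds that differ in only one place is available, so there is no direct precedent for a single change.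

Compound 3, `COc1ccc(/C=C2\CN(CC(=O)O)c3c(C)cccc3C2=O)cc1`, has not yet been measured in this assay. It differs from compound 2 in one place: methoxy in place of dimethylamino on an aromatic carbon. Among the compounds with values here, with no matching measured step to lean on, only a modest change is expected, and in either direction the step from compound 2 to compound 3 should stay near the scatter, estimated as a number 3.8 percentage points higher from compound 2 to compound 3 (within the scatter). Compound 3 is therefore expected to give about 17% in this assay, most likely somewhere between 5% and 30%.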

Compound 3, a percentage reported as inhibition, at one concentration (the size of the read-out at that concentration, not a potency): 31.5%
The estimate for compound 3 lay 14.5 percentage points below the measured number, and the stated range ends below it.
By their numbers in this assay, from the lowest: compound 2; then compounds 1 and 3 (each within the scatter of the next).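

For the compounds shown here, replacing dimethylamino with methoxy on an aromatic carbon, para to a large group, gives the first single-change comparison here, and in this assay it amounts to a number 18.3 percentage points higher from compound 2 to compound 3 (beyond the scatter) on otherwise matching structures. This position is therefore not indifferent to what it carries, even though the two groups have the same number of hydrogen-bond donors and acceptors and neither bears a net charge. Nothing measured alongside these compounds accounts for the rise.

Still open, on these data alone, is whether the rise is particular to methoxy, or whether a hydroxyl, a fluorine atom or a longer chain such as ethoxy on the same carbon would behave alike, and whether the same swap would give a similar step on a core carrying chlorine in place of the methyl group. The numbers also describe inhibition at one concentration only, so they give the size of the effect at that concentration and leave open how potency would compare across a range of concentrations.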